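A Benzoyl Group Takes the Place of Nitro

The compounds below may be only part of what the source reports. "The series", "measured", "known", "first", "only" and "open" are said of these compounds alone.

Of the compounds shown here, three have so far been measured in a functional assay on A549 cells (Homo sapiens) for inhibition, read by MTT assay, with a stated time of 48 h; on this read-out lower numbers stand for stronger inhibition and higher numbers for weaker inhibition. Compound 1 `O=Cc1cccc(OCc2cn(Cc3ccccc3)nn2)c1` returns only a limit of the assay, > 50000 nM. Compound 2 `COc1cc(Cn2cc(COc3cccc(/C=C4/C(=O)Nc5ccccc54)c3)nn2)cc(OC)c1` returns a number, 26700 nM. Compound 3 `O=C1Nc2ccc([N+](=O)[O-])cc2/C1=C\c1cccc(OCc2cn(Cc3ccccc3)nn2)c1` again returns only a limit of the assay, > 50000 nM. Compound 3 therefore stands among the compounds for which no number has yet been obtained; the account of the measurements so far is that (the limit of > 50000 nM in this assay, at which 2 of the 3 values shown sit), and compound 2 alone gives a value.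

Compound 4 `O=C1Nc2ccc(C(=O)c3ccccc3)cc2/C1=C\c1cccc(OCc2cn(Cc3ccccc3)nn2)c1` differs from compound 3 in one place: benzoyl in place of nitro on an aromatic carbon. Among the measured compounds shown here, no pair of measured compounds differs by this change, so nothing measured sets its size. For compound 4 a shift toward stronger inhibition of moderate size is expected, while a renewed limit remains a real possibility, so the expected step of an at least 1.6-fold lower number from compound 3 to compound 4 (0.22 log units; that floor lies within the scatter) is tentative. Compound 4 is estimated to give 30000 nM, between 10000 nM and 80000 nM.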

Compound 4, half-maximal inhibitory concentration: > 50000 nM
Compound 4: a limit, no number (the forecaster's own chance of this, stated with the estimate: 45%); at least 1.6-fold (0.22 log units) between middle value and limit.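

In this assay compound 3 and compound 4 each return only a limit of the assay, so no step can be read between them. The compounds shown leave open whether benzoyl in place of nitro on an aromatic carbon changes inhibition at all, with most values stopping at one point: the limit of > 50000 nM in this assay, at which 3 of the 4 values shown sit.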